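The compounds below may be only part of what the source reports. "The series", "measured", "known", "first", "only" and "open" are said of these compounds alone.

Four close analogues share one scaffold and differ in two places: the length of the linker that joins the two halves, and the aryl group that sits on the five-membered ring. Compound 1 `COC(=O)c1c(NCCNc2ccnc3cc(Cl)ccc23)noc1-c1ccccc1F` and compound 3 `COC(=O)c1c(NCCNc2ccnc3cc(Cl)ccc23)noc1-c1ccc(Cl)cc1Cl` carry the shorter linker; compound 2 `COC(=O)c1c(NCCCNc2ccnc3cc(Cl)ccc23)noc1-c1ccccc1F` and compound 4 `COC(=O)c1c(NCCCNc2ccnc3cc(Cl)ccc23)noc1-c1ccc(Cl)cc1Cl` carry the longer one. The difference between the two cores, compound 1 against compound 2, is not broken down here.

In an ADME assay on J774.A1 cells (Mus musculus) for cytotoxicity, read by MTT assay, with a stated time of 48 h (on this read-out lower numbers stand for higher toxicity in this test and higher numbers for lower toxicity in this test), compound 1 gives 3420 nM. The change 2,4-dichlorophenyl in place of 2-fluorophenyl on an aromatic carbon leads to compound 3, which in this assay gives 3450 nM; the step of a 1.0-fold higher number from compound 1 to compound 3 (0.00 log units; within the scatter) is within the scatter of the assay. For compound 2 the outcome in this assay is "not determined" (no result reported), so no number stands for it.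

The same change, (2,4-dichlorophenyl in place of 2-fluorophenyl on an aromatic carbon), made at the same place, converts compound 2 into compound 4. Because the step of a 1.0-fold higher number from compound 1 to compound 3 (0.00 log units; within the scatter) left the cytotoxicity unchanged on the shorter-linker core, the expectation is that this change will again be a small one on the longer-linker core, with the usual caveat that compound 2 itself offers no anchor and the expectation rests on compounds 1 and 3 alone. Compound 4 is therefore expected to fall in this assay at about 3400 nM. The estimated range for compound 4 runs from 1500 nM to 8000 nM.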

Compound 4, half-maximal cytotoxic concentration: 31100 nM
Compound 4: the middle estimate sits 9.1-fold (0.96 log units) below what was measured, and the stated range ends below it.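

No number stands for compound 2 in this assay so the step from it to compound 4 cannot be read. The compounds shown leave open whether the change to 2,4-dichlorophenyl from 2-fluorophenyl moves the cytotoxicity on the longer-linker core, where compound 4 gives 31100 nM and has no measured partner. Nothing available offers an explanation for the value of compound 4.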